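The source may report more compounds than this note shows. Statements on the series, on what has been measured and on what is new or still open speak of the compounds shown alone.

Going by the values given here, compound 2 `O=C(/C=C/c1ccc(OCc2nc(C3CCN(Cc4ccc(Br)cc4)CC3)no2)cc1)NO` stands at the lower of the two numbers measured so far: in an assay on isolated protein for inhibition of protein deacetylase HDAC6 (Homo sapiens), read by fluorescence, with a stated time of 1 h, tested at 100 nM (on this read-out lower numbers stand for less inhibition and higher numbers for more inhibition at the one concentration tested (going by the name of the read-out)), compound 2 gives 58%, while compound 1 `O=C(/C=C/c1ccc(OCc2nc(C3CCN(Cc4ccc(F)cc4F)CC3)no2)cc1)NO` gives 74%. Among the compounds with values here, the one measured step at this position, a number 16 percentage points lower from compound 1 to compound 2 (beyond the scatter), shows that changing the aryl group on the saturated chain carbon bound to the amine nitrogen in the ring moves the read-out by a modest amount. Compound 3 `O=C(/C=C/c1ccc(OCc2nc(C3CCN(Cc4ccccc4[N+](=O)[O-])CC3)no2)cc1)NO` differs from compound 2 by 2-nitrophenyl in place of 4-bromophenyl on a saturated chain carbon bound to an amine nitrogen in a ring. Within the data shown here, no measured step involves a nitrophenyl group, so the direction for compound 3 cannot be read from the data; the only guide is that compound 2 is the lowest number and a swap of this aryl group shifted the number modestly before. Compound 3 is therefore expected to lie near compound 2, with a step of a number 5 percentage points higher from compound 2 to compound 3 (within the scatter) within the scatter. The estimate for compound 3 is 63%, between 45% and 80%.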

Compound 3, a percentage reported as inhibition, at one concentration (the size of the read-out at that concentration, not a potency): 63%
For compound 3 middle estimate and measured number coincide at the digits printed, within the range that was stated.
By their numbers in this assay, from the lowest: compounds 2 and 3 (each within the scatter of the next); then compound 1.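

In this assay, 2-nitrophenyl in place of 4-bromophenyl gave a number 5 percentage points higher from compound 2 to compound 3 (within the scatter), so this position does not tell these two aryl groups apart on this read-out, although 2-nitrophenyl brings a double bond outside aromatic rings and hydrogen-bond acceptors that 4-bromophenyl lacks. Going by these compounds alone, the same group in place of 2,4-difluorophenyl gave a number 11 percentage points lower from compound 1 to compound 3 (beyond the scatter), which leaves 2,4-difluorophenyl as the one aryl group of the three that stands apart from the other two. Nothing available on these compounds accounts for either step.

The compounds shown leave open whether 4-nitrophenyl would match 2-nitrophenyl, and how an aryl ring carrying an amine or a carboxylic acid would read at this position. They also leave open what a longer chain in place of the saturated chain carbon would do.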